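The compounds below may be only part of what the source reports. "The series", "measured", "known", "first", "only" and "open" are said of these compounds alone.

Measured so far in a functional assay on MCF7 cells (Homo sapiens) for antiproliferative activity, read by MTT assay, with a stated time of 48 h; on this read-out higher numbers stand for weaker inhibition and lower numbers for stronger inhibition:
compound 1, `N=C(N)N/N=C(/C=C/c1ccc(F)cc1)c1ccccc1`: 2500 nM
compound 2, `COc1ccc(/C=C/C(=N/NC(=N)N)c2ccccc2)cc1`: 14000 nM
compound 3, `N=C(N)N/N=C(/C=C/c1cccc(F)c1)c1ccccc1`: 16000 nM

Compound 1 stands apart, with a 5.6-fold higher number from compound 1 to compound 2 (0.75 log units; beyond the scatter) and a 6.4-fold higher number from compound 1 to compound 3 (0.81 log units; beyond the scatter), both beyond the scatter; compound 2 and compound 3 lie within the scatter of each other, so no order is read between them. The change from compound 1 to compound 2 is methoxy in place of fluoro on an aromatic carbon. The same kind of change separates compound 4, `COc1cccc(/C=C/C(=N/NC(=N)N)c2ccccc2)c1`, from compound 3: methoxy in place of fluoro on an aromatic carbon. The two cores differ as 3-fluorophenyl in place of 4-fluorophenyl on a double-bonded chain carbon bound to a double-bonded chain carbon. The place is not the same word for word: in the first pair the group sits para to a large group, in the second meta to a large group, so the earlier step is a guide rather than a copy. The step expected from compound 3 to compound 4 in this assay is a 3.1-fold higher number from compound 3 to compound 4 (0.49 log units; beyond the scatter), set beside a 5.6-fold higher number from compound 1 to compound 2 (0.75 log units; beyond the scatter) and resting on compound 3 at 16000 nM. Compound 4 is expected at 50000 nM, with a range from 15000 nM to 150000 nM.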

Compound 4, half-maximal inhibitory concentration: 13000 nM
Compound 4: the middle estimate sits 3.8-fold (0.59 log units) above what was measured; measured number below the stated range.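

In this assay, methoxy in place of fluoro on an aromatic carbon, meta to a large group, gives a 1.2-fold lower number from compound 3 to compound 4 (0.09 log units; within the scatter), so the step seen on the core of compound 1 does not carry over to the core of compound 3: the same change on two cores in this assay, a 5.6-fold higher number (0.75 log units; beyond the scatter) from compound 1 to compound 2 and a 1.2-fold lower number (0.09 log units; within the scatter) from compound 3 to compound 4, 6.9-fold (0.84 log units) apart, beyond the scatter of two such steps

In this series, then, the result of this change depends on the core that carries it, and the step from one pair cannot simply be transferred to the other, even though the two cores differ only as 3-fluorophenyl in place of 4-fluorophenyl. Two pairs in one assay do not show why the steps part, nor which of them, if either, a further core would follow.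

Open, from the compounds shown here alone, is whether a chloro, a hydroxy or an amino group would track fluoro or methoxy on either core. Also open, going by these compounds, is whether a longer chain such as ethoxy would behave as methoxy does on these two cores.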